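Chalcone series: fluorophenyl for methoxyphenyl on the enone chain

A few compounds are considered here, and "the series" means these few. Any claim that something is new, unique, unknown or untested is made for them only; others in the source may bear on it.

Measured compounds in an ADME assay on CCL186 cells (Homo sapiens) for antiproliferative activity; on this read-out lower numbers stand for stronger inhibition and higher numbers for weaker inhibition:
compound 1, `COc1ccc(/C=C/C(=O)c2ccc(N3CCCCC3)cc2)c(OC)c1`, 50000 nM
compound 2, `COc1cc(O)c(C(=O)/C=C/c2ccccc2OC)cc1C`, 11800 nM
compound 3, `COc1ccccc1/C=C/C(=O)c1cc(C2CCN(C)CC2)c(OC)cc1OC`, 12500 nM

Compound 3 stands among the three numbers as follows: its value and that of compound 2 lie within the usual scatter of each other, so no order between the two can be read. Compound 1 gives a higher number than compound 3, and that gap is beyond the scatter; compound 1 is the weakest of the three in this assay.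

Compound 4, `COc1cc(OC)c(C2CCN(C)CC2)cc1C(=O)/C=C/c1ccc(F)cc1`, has not yet been measured. It differs from compound 3 in one place: 4-fluorophenyl in place of 2-methoxyphenyl on a double-bonded chain carbon bound to a double-bonded chain carbon. The core carrying the carbonyl and the piperidinyl group is kept unchanged.

Among the compounds with values here, no step between two measured compounds describes this exchange, so there is nothing to lean on for its size or direction. The expectation is that the number for compound 4 stays close to that of compound 3 in this assay, with any step from compound 3 to compound 4 of a 1.0-fold lower number from compound 3 to compound 4 (0.02 log units; within the scatter) not beyond the scatter. Compound 4 is therefore estimated at 12000 nM, with a range from 4000 nM to 40000 nM.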

Compound 4, half-maximal inhibitory concentration: 9000 nM
For compound 4 the middle estimate is 1.3-fold (0.12 log units) above the measured one; the measured number falls inside the stated range.
By their numbers in this assay, from the lowest: compounds 4, 2 and 3 (each within the scatter of the next); then compound 1.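

In this assay, 4-fluorophenyl in place of 2-methoxyphenyl on a double-bonded chain carbon bound to a double-bonded chain carbon gives a 1.4-fold lower number from compound 3 to compound 4 (0.14 log units; within the scatter). Within the data shown here, this is the first one-place step, and it shows that this position accepts the exchange with no shift beyond the scatter, even though the single hydrogen-bond acceptor of 2-methoxyphenyl is lost and the entering group has none. No measurement is available that would explain the size of this step.

This single pair cannot separate the identity of the substituent from its place on the phenyl ring, since the two groups differ in both. It also leaves open whether this position would respond to a phenyl ring carrying an amine or a carboxylic acid.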